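Replacing methoxy with trifluoromethyl on the shared core

This account rests on a few compounds, and the source may have more. Where it says the series, first, only, none or still open, it means among the compounds named here.

Of the compounds shown here, two sharing one core have been measured so far: compound 1 (`CCOC(=O)c1c(-c2cccc(OCC)c2)[nH]c2cc(OC)ccc2c1=O`) and compound 2 (`CCOC(=O)c1c(-c2cccc(OC(F)(F)F)c2)[nH]c2cc(OC)ccc2c1=O`). In an ADME assay on BJ cells (Homo sapiens) for cytotoxicity, read by luminescence, with a stated time of 72 h (on this read-out lower numbers stand for an effect already at smaller amounts and higher numbers for an effect only at larger amounts of compound), compound 1 gives > 21500 nM, which is a limit of the assay and not a number. Compound 2 gives > 21500 nM, which is also a limit. No number therefore places compound 2. Among the compounds with values here, the only measured step, a step that the two limits leave unreadable from compound 1 to compound 2, has no readable size, and it lies at a different place on the molecule from the change considered here.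

Compound 3 (`CCOC(=O)c1c(-c2cccc(OC(F)(F)F)c2)[nH]c2cc(C(F)(F)F)ccc2c1=O`) keeps the rest of compound 2 but carries trifluoromethyl in place of methoxy on an aromatic carbon. Within the data shown here, no measured step gives a size for this change. No step beyond the scatter is expected in this assay, in either direction, because compound 2 sits at the limit of > 21500 nM in this assay, at which 2 of the 2 values shown sit. The estimated step that the limit leaves unreadable from compound 2 to compound 3 is accordingly small. For compound 3 the expected value is 25000 nM, with an estimated range from 12000 nM to 50000 nM, and another limit is the most likely report.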

Compound 3, half-maximal effective concentration: > 21500 nM
Compound 3 gave a limit, no number (the forecaster's own chance of this, stated with the estimate: 85%); the middle value lies beyond the limit too.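

In this assay compound 3 gives > 21500 nM, which is a limit and not a number. Within the data shown here, no step can therefore be read between compound 2 and compound 3, and all three compounds share one reading: the limit of > 21500 nM in this assay, at which 3 of the 3 values shown sit.

The compounds shown leave open at what concentration any of them would show an effect, and whether trifluoromethyl in place of methoxy changes that concentration at all.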